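From isopropyl to 4-methylphenyl on an aromatic nitrogen

The compounds below may be only part of what the source reports. "The series", "measured", "known", "first", "only" and "open" are said of these compounds alone.

In a functional assay on T47D cells (Homo sapiens) for antiproliferative activity, read by MTT assay, with a stated time of 72 h (a higher number here means a weaker inhibitor, a lower number a stronger inhibitor), compound 1, `COc1cc(-c2nccn2C(C)C)cc(OC)c1OC`, gives > 100000 nM, which is a limit of the assay and not a number. That puts compound 1 at the limit of > 100000 nM in this assay, at which 1 of the 3 values shown sits.

Two relatives do give numbers. Compound 2, `COc1ccc(-n2ccnc2-c2cc(OC)c(OC)c(OC)c2)cc1[N+](=O)[O-]`, shows 10000 nM, and compound 3, `COc1cc(-c2nccn2-c2ccc3cc[nH]c3c2)cc(OC)c1OC`, shows 18000 nM. These two values lie within the usual scatter of each other, so they count as one level of activity.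

The next compound to be measured is compound 4, `COc1cc(-c2nccn2-c2ccc(C)cc2)cc(OC)c1OC`. It keeps the core of compound 1 but carries 4-methylphenyl in place of isopropyl on an aromatic nitrogen, the nitrogen of a five-membered aromatic ring with 2 nitrogen: 4-methylphenyl in place of isopropyl on an aromatic nitrogen.

Going by the values given here, no pair of measured compounds shows this change on its own, so any forecast is indirect. Compound 2 at 10000 nM and compound 3 at 18000 nM both have an aromatic group on that nitrogen, and both give a real number. A clear move towards stronger inhibition therefore seems likely in this assay. The expected size of the move is an at least 5.0-fold lower number from compound 1 to compound 4 (0.69 log units; beyond the scatter). For compound 4 the estimated value is 20000 nM, with an expected range from 7000 nM to 70000 nM.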

Compound 4, half-maximal inhibitory concentration: 20500 nM
For compound 4 the middle estimate is 1.0-fold (0.01 log units) below the measured one; the range from low to high includes it.
By their numbers in this assay, from the lowest: compounds 2, 3 and 4 (each within the scatter of the next, the first and the last beyond it). At a limit, above all of these: compound 1.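

In this assay, the change can now be read on its own: with the core of compound 1 held fixed, 4-methylphenyl in place of isopropyl on the aromatic nitrogen gives an at least 4.8-fold lower number from compound 1 to compound 4 (0.68 log units; beyond the scatter). Going by these compounds alone, no earlier pair isolated this change, so this is the first direct sign that activity in this assay depends on the group carried at this position, and the step lies beyond the usual scatter. Its true size stays unknown because compound 1 sits at a limit of the assay and not at a number, so the step has a bound but no end point: the limit of > 100000 nM in this assay, at which 1 of the 4 values shown sits.

The compounds shown do not tell whether the gain comes from the aromatic ring itself or simply from the added carbon atoms, a question that a longer chain such as n-butyl on the same nitrogen would help to settle. Also open, as far as these compounds go, is what the methyl group contributes, which could be tested by comparing 4-methylphenyl with plain phenyl, or with a phenyl ring carrying an amine or a carboxylic acid in its place.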